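From a Nitrile to a Dimethylamide on the Side Chain

The source may report more compounds than this note shows. Statements on the series, on what has been measured and on what is new or still open speak of the compounds shown alone.

Measured compounds:
compound 1 `C=CCc1cc(C(C)=O)c(O)cc1OCCCCCC#N`: 81%
compound 2 `CC(=O)c1cc(C(C)(C)C)c(OCCCCCC(C)(C)C#N)cc1O`: 1%

In an assay on isolated protein for inhibition of leukotriene B4 receptor 1 (Homo sapiens), tested at 10 uM (on this read-out higher numbers stand for more inhibition at the one concentration tested (going by the name of the read-out) and lower numbers for less inhibition), compound 1 gives 81%, the highest of the two numbers shown. Compound 2 gives 1%, a number beyond the scatter below compound 1. Compound 3 `C=CCc1cc(C(C)=O)c(O)cc1OCCCCCC(=O)N(C)C` has not yet been measured in this assay. It differs from compound 1 by dimethylcarbamoyl in place of cyano on a saturated chain carbon, five bonds along the chain from an oxygen on an aromatic ring. Among the compounds with values here, no measured pair shows this change alone, so the size of the step rests on expectation only. The step of a number 21 percentage points lower from compound 1 to compound 3 (beyond the scatter) is expected to be a moderate loss, beyond the scatter. Compound 3 is estimated at 60%, between 25% and 85%.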

Compound 3, a percentage reported as inhibition, at one concentration (the size of the read-out at that concentration, not a potency): 92%
Compound 3: the middle estimate sits 32 percentage points below what was measured; measured number above the stated range.
By their numbers in this assay, from the lowest: compound 2; then compound 1; then compound 3.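

In this assay dimethylcarbamoyl in place of cyano on a saturated chain carbon, five bonds along the chain from an oxygen on an aromatic ring, gives a number 11 percentage points higher from compound 1 to compound 3 (beyond the scatter) and so the nitrile is not required at this position. The position accepts a group of five heavy atoms where cyano has two, with no loss of inhibition at the one concentration tested. Nothing at hand explains why the number rises.

From the compounds shown here alone, whether a carboxylic acid or an amine at this place would hold the inhibition stays open. So does the effect of a longer or shorter chain carrying the dimethylcarbamoyl group.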